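Furan in Place of Chlorophenyl: Expected Vero Cell Growth Inhibition

A few compounds are considered here, and "the series" means these few. Any claim that something is new, unique, unknown or untested is made for them only; others in the source may bear on it.

Compound 1, `CC1=CC[C@H](C(C)(C)NC(=S)N/N=C/c2ccccc2)CC1`: in an ADME assay on Vero cells (Chlorocebus sabaeus) for inhibition, read by sulforhodamine B assay, with a stated time of 48 h (on this read-out lower numbers stand for stronger inhibition of growth and higher numbers for weaker inhibition of growth), compound 1 gives > 100000 nM, a limit of the assay.
Compound 2, `CC1=CC[C@H](C(C)(C)NC(=S)N/N=C/c2cccc(Cl)c2)CC1`: in this assay compound 2 gives > 100000 nM, again a limit.
Compound 3, `CC1=CC[C@H](C(C)(C)NC(=S)N/N=C/c2ccc(Cl)cc2)CC1`: in this assay compound 3 gives > 100000 nM, also a limit.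

Compound 3 therefore stands at the limit, not at a number, and its two companions stand there as well (the limit of > 100000 nM in this assay, at which 3 of the 3 values shown sit). The three measured steps, a step that the two limits leave unreadable from compound 1 to compound 2, a step that the two limits leave unreadable from compound 1 to compound 3 and a step that the two limits leave unreadable from compound 2 to compound 3, all remain unreadable because every value sits at the limit of > 100000 nM in this assay, at which 3 of the 3 values shown sit; they tell nothing about how large a change a swap on the aromatic ring can bring.

Compound 4, `CC1=CC[C@H](C(C)(C)NC(=S)N/N=C/c2ccco2)CC1`, carries the change (furan-2-yl in place of 4-chlorophenyl on a carbon with a double bond to nitrogen). The measured steps bear on it only in showing that three different aromatic groups at this position all left growth inhibition beyond the measured range. Among the measured compounds shown here, compound 4 is expected to behave the same way, so the step that the limit leaves unreadable from compound 3 to compound 4 is estimated to be no real step at all. Compound 4 is expected to give 150000 nM, with a range from 50000 nM to 500000 nM, most likely reported again as a limit.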

Compound 4, concentration for total growth inhibition: 14700 nM
Compound 4: middle estimate off by 10-fold (1.01 log units), on the high side, and the stated range ends above it.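

In this assay, furan-2-yl in place of 4-chlorophenyl gives an at least 6.8-fold lower number from compound 3 to compound 4 (0.83 log units; beyond the scatter), furan-2-yl in place of 3-chlorophenyl gives an at least 6.8-fold lower number from compound 2 to compound 4 (0.83 log units; beyond the scatter), and furan-2-yl in place of phenyl gives an at least 6.8-fold lower number from compound 1 to compound 4 (0.83 log units; beyond the scatter). The group on the carbon with a double bond to nitrogen can therefore change growth inhibition, which compound 1, compound 2 and compound 3 could not show on their own. These steps give only minimum sizes, and the steps among those three compounds still cannot be read, because all three values are limits: the limit of > 100000 nM in this assay, at which 3 of the 4 values shown sit.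

As far as these compounds go, it remains open whether the change follows the ring oxygen or the five-membered ring itself. A thiophen-2-yl or pyrrol-2-yl group at this place would help separate the two.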